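The compounds below may be only part of what the source reports. "The series", "measured", "known", "first", "only" and "open" are said of these compounds alone.

Three compounds share one core and differ only in small groups hung on it. Compound 1 `CCS[C@@H]1[C@H](SCC)[C@@H](Cn2cc(-c3ccccc3)nn2)O[C@H]1n1ccc(=O)[nH]c1=O` carries a phenyl on its five-membered ring with three nitrogens; in a functional assay on LAC cells (Homo sapiens) for cytotoxicity, read by MTT assay, with a stated time of 72 h (a higher number here means that more compound is needed for the effect, a lower number that less compound is needed), compound 1 has "not determined" (no result reported). Compound 2 `CCS[C@@H]1[C@H](SCC)[C@@H](Cn2cc(-c3ccc(F)cc3)nn2)O[C@H]1n1ccc(=O)[nH]c1=O` carries a 4-fluorophenyl instead, and in this assay compound 2 gives 72400 nM. Compound 3 `CCS[C@@H]1[C@H](SCC)[C@@H](Cn2cc(-c3ccc(F)cc3)nn2)O[C@H]1n1cc(C)c(=O)[nH]c1=O` adds a methyl on an aromatic carbon. In this assay compound 3 reaches only a limit of the assay, >= 100000 nM, so no single number is known for it. The step of an at least 1.3-fold higher number from compound 2 to compound 3 (0.14 log units; that floor lies within the scatter) is small and rests on that limit; compound 3 therefore stands, like compound 1, among the entries without a single number, a position marked by the limit of >= 100000 nM in this assay, at which 1 of the 3 values shown sits.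

Compound 4 `CCOC(=O)c1cn(C[C@H]2O[C@@H](n3cc(C)c(=O)[nH]c3=O)[C@H](SCC)[C@@H]2SCC)nn1` differs from compound 3 by ethoxycarbonyl in place of 4-fluorophenyl on an aromatic carbon. For the measured compounds named here, no measured step touches this change: the only step at hand, an at least 1.3-fold higher number from compound 2 to compound 3 (0.14 log units; that floor lies within the scatter), concerns another place on the core. With no guide, no shift beyond the scatter is expected, and the step of a number no higher from compound 3 to compound 4 (the limit leaves the size open) is the estimate. In this assay compound 4 is expected to give about 100000 nM, between 40000 nM and 250000 nM.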

Compound 4, half-maximal effective concentration: >= 100000 nM
Compound 4: no number, only a limit (the forecaster's own chance of this, stated with the estimate: 70%); the middle value sits exactly at the limit.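

Compound 3 and compound 4 each reach only a limit of the assay, so no step between them can be read: the limit of >= 100000 nM in this assay, at which 2 of the 4 values shown sit.

The compounds shown leave open how much of compound 3 or compound 4 is needed for the effect in this assay, and whether ethoxycarbonyl and 4-fluorophenyl differ there at all.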